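Same Fluoro Step, Now Tried on a Weaker Core

A few compounds are considered here, and "the series" means these few. Any claim that something is new, unique, unknown or untested is made for them only; others in the source may bear on it.

Compound 1 `O=C1Nc2ccccc2C1CCCCN1CCN(c2cccc(Cl)c2)CC1` and compound 2 `O=C1Nc2cc(F)ccc2C1CCCCN1CCN(c2cccc(Cl)c2)CC1` share one core and differ in a single spot: fluoro in place of hydrogen on an aromatic carbon. In an assay on membranes from frontal cortex for displacement of a labelled ligand from Adrenergic receptor alpha-1 (Rattus norvegicus), read by scintillation counting, with a stated time of 45 min (a lower number here means a stronger inhibitor, a higher number a weaker inhibitor), compound 1 gives 26 nM, while compound 2 gives 12.5 nM, so this change brought a 2.1-fold lower number from compound 1 to compound 2 (0.32 log units; beyond the scatter).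

Compound 3 `O=C1Nc2ccccc2C1CCCCN1CCN(c2ccccn2)CC1` keeps the core of compound 1 but carries another group on the ring nitrogen: pyridin-2-yl in place of 3-chlorophenyl on an amine nitrogen in a ring. In this assay compound 3 gives 130 nM, which is a 5.0-fold higher number from compound 1 to compound 3 (0.70 log units; beyond the scatter) and the highest number among the three measured compounds.

Compound 4 `O=C1Nc2cc(F)ccc2C1CCCCN1CCN(c2ccccn2)CC1` has not yet been measured. It stands to compound 3 exactly as compound 2 stands to compound 1: fluoro in place of hydrogen on an aromatic carbon. The surroundings of the change are described in the same words for both pairs, so it is the same change, made a second time, only on the core of compound 3.

What can be expected of compound 4 rests on one earlier example of this change, a 2.1-fold lower number from compound 1 to compound 2 (0.32 log units; beyond the scatter), and on the value of compound 3, 130 nM. Within the data shown here, with only one precedent, the expected step is kept close to that example while allowing for the usual scatter. For compound 4 the step is estimated as a 2.0-fold lower number from compound 3 to compound 4 (0.30 log units; within the scatter) in this assay. Compound 4 is therefore expected to give about 65 nM in this assay. The range for compound 4 is estimated to run from 30 nM to 150 nM.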

Compound 4, inhibition constant: 33 nM
Estimate against measurement, compound 4: 2.0-fold (0.29 log units) above; the measured number falls inside the stated range.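

In this assay the fluoro change again lowered the number, giving a 3.9-fold lower number from compound 3 to compound 4 (0.60 log units; beyond the scatter), so it carried over from the core of compound 1 to the core of compound 3 in direction, and the two steps do not differ beyond the scatter: the same change on two cores in this assay, a 2.1-fold lower number (0.32 log units; beyond the scatter) from compound 1 to compound 2 and a 3.9-fold lower number (0.60 log units; beyond the scatter) from compound 3 to compound 4, 1.9-fold (0.28 log units) apart, within the scatter of two such steps. The other change, pyridin-2-yl in place of 3-chlorophenyl, behaved the same way on the fluorinated core, giving a 2.6-fold higher number from compound 2 to compound 4 (0.42 log units; beyond the scatter), again in line with its earlier step: the same change on two cores in this assay, a 5.0-fold higher number (0.70 log units; beyond the scatter) from compound 1 to compound 3 and a 2.6-fold higher number (0.42 log units; beyond the scatter) from compound 2 to compound 4, 1.9-fold (0.28 log units) apart, within the scatter of two such steps. These two pairs show that, across these four compounds in a single assay, each change kept its direction whichever form the other part of the molecule took; they give no ground for calling either fluoro step the larger one, and they do not show that the change would carry over to any other core, or why it lowers the number here.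

The compounds shown leave open whether chloro or methoxy in the same place on the aromatic ring would follow the fluoro step, and whether fluoro on another carbon of that ring would do so. They also leave open whether either step would hold with a shorter or longer chain joining the core to the ring nitrogen.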